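The compounds below may be only part of what the source reports. "The series", "measured", "known", "first", "only" and "open" are said of these compounds alone.

Measured compounds:
compound 1, `COc1ccc(Nc2nc(/C=C/c3ccccc3)nc3ccsc23)cc1`, > 1000000 nM
compound 2, `FC(F)(F)c1ccc(Nc2nc(/C=C/c3ccccc3)nc3ccsc23)cc1`, > 1000000 nM
compound 3, `COc1ccc(Nc2nc(/C=C/c3cc(OC)c(OC)c(OC)c3)nc3ccsc23)cc1`, 279000 nM

All three were tested in a functional assay on L02 cells (Homo sapiens) for inhibition, read by Griess assay, with stated times of 1 h and 24 h; on this read-out higher numbers stand for weaker inhibition and lower numbers for stronger inhibition. Compound 1 gives > 1000000 nM, which is a limit of the assay rather than a number. Compound 2 likewise gives > 1000000 nM, again a limit and not a number. Among the measured compounds shown here, compound 3 is the only one with a measured number, 279000 nM. Compound 1 and compound 2 differ in one place: trifluoromethyl in place of methoxy on an aromatic carbon. The step that the two limits leave unreadable from compound 1 to compound 2 cannot be read, because both values sit at the limit of > 1000000 nM in this assay, at which 2 of the 3 values shown sit. Compound 3 carries a different core from compound 1; the difference between the two cores is not broken down here.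

Compound 4, `COc1cc(/C=C/c2nc(Nc3ccc(C(F)(F)F)cc3)c3sccc3n2)cc(OC)c1OC`, has not been measured in this assay. It stands to compound 3 as compound 2 stands to compound 1: trifluoromethyl in place of methoxy on an aromatic carbon. The place is the same word for word in both pairs, so this is the same change. The measured pair offers no size for it, since a step that the two limits leave unreadable from compound 1 to compound 2 is unreadable. The expectation for compound 4 therefore rests only on compound 3 and its value 279000 nM, and leaves wide room on either side. The step from compound 3 to compound 4 is expected to be about a 1.4-fold higher number from compound 3 to compound 4 (0.16 log units; within the scatter). Compound 4 is then estimated at 400000 nM, within a range from 120000 nM to 1500000 nM.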

Compound 4, half-maximal inhibitory concentration: 436000 nM
Beside the measured number, compound 4's estimate is 1.1-fold (0.04 log units) below it; measured number inside the range.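

In this assay, putting trifluoromethyl in place of methoxy on the core of compound 3 gives a 1.6-fold higher number from compound 3 to compound 4 (0.19 log units; within the scatter), so on this core the two groups cannot be told apart by this read-out. The same change on the core of compound 1 cannot be read, because compound 1 and compound 2 both sit at a limit and not at a number: the limit of > 1000000 nM in this assay, at which 2 of the 4 values shown sit. Among the compounds shown here, one readable pair therefore shows only that the change has no size beyond the usual scatter on one core; it does not show that the change behaves alike on both cores, and the other core offers no size to compare with it.

The compounds shown hold only methoxy or trifluoromethyl on this aromatic carbon, which leaves open what another group there, such as an amine, a carboxylic acid or a nitrile, would do on either core. Also open, from the compounds shown here alone, is whether a longer chain in place of the methoxy groups that set the core of compound 3 apart from the core of compound 1 would give a number clearly different from those of compound 3 and compound 4.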